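Notes on an Amine Ring Exchange in a Weak Series

The source may report more compounds than this note shows. Statements on the series, on what has been measured and on what is new or still open speak of the compounds shown alone.

In a functional assay on HeLa cells (Homo sapiens) for inhibition, read by MTT assay, with a stated time of 48 h (on this read-out lower numbers stand for stronger inhibition and higher numbers for weaker inhibition), compound 1 `CN1CCN(c2ccc(Nc3ncc4c(n3)N(C3CCCC3)CC(=O)N4)nc2)CC1` gives > 30000 nM, a limit of the assay.
Compound 2 `CC1CCN(c2ccc(Nc3ncc4c(n3)N(C3CCCC3)CC(=O)N4)nc2)CC1` gives > 30000 nM in this assay, also a limit.
Compound 3 `CCN1C(=O)CN(C2CCCC2)c2nc(Nc3ccc(N4CCN(C)CC4)cn3)ncc21` gives 29100 nM in this assay.

Compound 3 is the only one of the three with an actual number in this assay; the other two values are limits. The step of an at least 1.0-fold lower number from compound 1 to compound 3 (0.01 log units; that floor lies within the scatter) lies within the scatter. Compound 4 `CCN1C(=O)CN(C2CCCC2)c2nc(Nc3ccc(N4CCC(C)CC4)cn3)ncc21` has not been measured; it differs from compound 3 by 4-methylpiperidin-1-yl in place of 4-methylpiperazin-1-yl on an aromatic carbon. The same exchange is seen between compound 1 and compound 2, but the step that the two limits leave unreadable from compound 1 to compound 2 cannot be read because both values sit at the limit of > 30000 nM in this assay, at which 2 of the 3 values shown sit. The exchange therefore has no readable precedent here, and no step beyond the scatter is expected, a 1.0-fold higher number from compound 3 to compound 4 (0.01 log units; within the scatter). Compound 4 is expected to give about 30000 nM in this assay, within 12000 nM to 75000 nM, with a real chance that only a limit is returned.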

Compound 4, half-maximal inhibitory concentration: > 30000 nM
Compound 4: only a limit was reported; the forecaster's own chance of this, stated with the estimate: 50%; the middle value lies on the limit itself.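

Within the data shown here, with ethyl on the amide-type ring nitrogen, 4-methylpiperidin-1-yl in place of 4-methylpiperazin-1-yl gives a first bound on this exchange in this assay, namely an at least 1.0-fold higher number from compound 3 to compound 4 (0.01 log units; that floor lies within the scatter) and nothing more. At this place, on the aromatic carbon, the exchange brings no lower number, which the pair compound 1 and compound 2 could not show. The steps joining two limits cannot be read: the limit of > 30000 nM in this assay, at which 3 of the 4 values shown sit.

Going by these compounds, whether morpholin-4-yl or an unsubstituted piperazin-1-yl at this place would give a number clearly under the limit stays open. So does the effect of a longer chain on the amide-type nitrogen.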